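Swapping the aryl group of compound 2: an expectation

This account rests on a few compounds, and the source may have more. Where it says the series, first, only, none or still open, it means among the compounds named here.

Measured so far, in an assay on cells for inhibition of sodium- and chloride-dependent glycine transporter 1 (Homo sapiens); on this read-out higher numbers stand for an effect only at larger amounts of compound and lower numbers for an effect already at smaller amounts:
Compound 1 `COc1cc(C(F)(F)F)cc(SC)c1C(=O)NC1(c2ccc(Cl)cc2)CCCN(C)C1` gives 28 nM.
Compound 2 `COc1cc(C(F)(F)F)cc(SC)c1C(=O)NC1(c2cccc(Cl)c2)CCCN(C)C1` gives 25 nM.

Going by the values given here, on these two numbers compound 2 stands with the lowest value, but the only step that connects them, a 1.1-fold lower number from compound 1 to compound 2 (0.05 log units; within the scatter), lies within the scatter, so the two compounds cannot be told apart. Among the compounds with values here, that step moved a chlorine around the aromatic ring and is the sole measured comparison available.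

Compound 3 `COc1cc(C(F)(F)F)cc(SC)c1C(=O)NC1(c2ccc(F)cn2)CCCN(C)C1` takes the next step: 5-fluoropyridin-2-yl in place of 3-chlorophenyl on a saturated ring carbon. Within the data shown here, no measured step exchanges the ring itself for one carrying a nitrogen, so the earlier step bears on this change only loosely, showing that altering this aryl group left this assay unmoved beyond the scatter. Without a direct precedent, a modest shift toward a higher number is expected rather than a large one; as an estimate, the step of a 2.0-fold higher number from compound 2 to compound 3 (0.30 log units; within the scatter) is anticipated. Compound 3 is therefore expected to give about 50 nM, with a plausible range from 15 nM to 170 nM.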

Compound 3, half-maximal effective concentration: 180 nM
Beside the measured number, compound 3's estimate is 3.6-fold (0.56 log units) below it; the measured number lies above the stated range.
By their numbers in this assay, from the lowest: compounds 2 and 1 (each within the scatter of the next); then compound 3.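

The two chlorophenyl compounds could not be told apart in this assay, but this position does respond when the aryl group itself is exchanged. Putting 5-fluoropyridin-2-yl in place of 3-chlorophenyl gives a 7.2-fold higher number from compound 2 to compound 3 (0.86 log units; beyond the scatter), and putting it in place of 4-chlorophenyl gives a 6.4-fold higher number from compound 1 to compound 3 (0.81 log units; beyond the scatter), so both comparisons, each beyond the scatter, point the same way. No measurement shown here explains the higher number.

This exchange puts a ring nitrogen in and swaps chlorine for fluorine at once, so the compounds shown leave open which of the two accounts for the step. A 4-fluorophenyl group or a 5-chloropyridin-2-yl group at this position would separate the two changes.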